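Alkenyl amide lengthening in the shared-core series: compound 3 to 4

The source may hold more compounds than are shown below. What is called first, only, known or untested is meant among the compounds shown, and "the series" means these compounds.

Measured so far:
Compound 1 `COc1ccc(Nc2nc(Oc3cccc(NC(=O)C=C(C)C)c3)c3sccc3n2)cc1`: 28800 nM
Compound 2 `COc1ccc(Nc2nc(Oc3cccc(NC(=O)/C=C/C(C)C)c3)c3sccc3n2)cc1`: 45100 nM
Compound 3 `C=CC(=O)Nc1cccc(Oc2nc(Nc3cccc(OC)c3)nc3ccsc23)c1`: 16400 nM

In a functional assay on HeLa cells (Homo sapiens) for inhibition, read by MTT assay, with a stated time of 72 h (a lower number here means a stronger inhibitor, a higher number a weaker inhibitor), compound 3 gives the smallest of the three numbers; its gap to compound 1 lies within the scatter, its gap to compound 2 beyond it. Compound 4 `C/C=C/C(=O)Nc1cccc(Oc2nc(Nc3cccc(OC)c3)nc3ccsc23)c1` is not yet measured. It differs from compound 3 in one place: prop-1-en-1-yl in place of vinyl on a carbonyl carbon. Among the measured compounds shown here, the single measured step that bears on this is the lengthening of the alkenyl chain on the carbonyl carbon in the other amide pair, a 1.6-fold higher number from compound 1 to compound 2 (0.19 log units; within the scatter), a change of the same kind that produced nothing beyond the scatter. For the measured compounds named here, only that one pair is available as precedent, and it was read on a differently substituted amide, so its weight is limited. On that basis no step beyond the scatter is expected in this assay on going from compound 3 to compound 4, with a slight lean toward a higher number. Compound 4 is therefore estimated at 21000 nM, with a range from 8000 nM to 55000 nM. The step this implies is expected to be a 1.3-fold higher number from compound 3 to compound 4 (0.11 log units; within the scatter).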

Compound 4, half-maximal inhibitory concentration: 20100 nM
Compound 4: middle estimate off by 1.0-fold (0.02 log units), on the high side; low and high end bracket the measured number.
By their numbers in this assay, from the lowest: compounds 3, 4, 1 and 2 (each within the scatter of the next, the first and the last beyond it).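

In this assay, prop-1-en-1-yl in place of vinyl on a carbonyl carbon whose other neighbour is an amide-type nitrogen gives a 1.2-fold higher number from compound 3 to compound 4 (0.09 log units; within the scatter), so this position takes the change from vinyl without a step that can be told from the scatter. Alongside a 1.6-fold higher number from compound 1 to compound 2 (0.19 log units; within the scatter), this gives two pairs, on differently substituted amides, in which a change in the alkenyl group on the carbonyl carbon stays within the scatter, although the two pairs start from different groups and neither has a step beyond it. No measured evidence is at hand that would account for the size of either step.

Still open, from the compounds shown here alone, is whether a saturated propyl chain, an alkyne, or a longer alkenyl chain ending in a dimethylamino group on the same carbonyl carbon would also stay within the scatter of compound 3 or move the number beyond it. The compounds shown also leave open whether a change at this position would look as small in any read-out other than this assay on these cells.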